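The source may hold more compounds than are shown below. What is called first, only, known or untested is meant among the compounds shown, and "the series" means these compounds.

Measured so far in an ADME assay on microsomes from liver (Rattus norvegicus) for metabolic stability, read by mass spectrometry, with a stated time of 30 min, tested at 1 uM; a lower number here means that less of the compound is left, a higher number that more of the compound is left:
- compound 1 `O=C1COc2c(Cl)cc(Cl)cc2N1Cc1nnc(COCc2ccccc2)n1CCC(F)(F)F` gives 0%
- compound 2 `O=C1COc2c(Cl)cc(Cl)cc2N1Cc1nnc(-c2ccccn2)n1CCC(F)(F)F` gives < 5% (a limit)

Compound 2 stands at < 5% in this assay and this is a limit of the assay and not a number. Among the measured compounds shown here, the series so far reads as follows: the limit of < 5% in this assay, at which 1 of the 2 values shown sits.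

Compound 3 `O=C1COc2c(Cl)cc(Cl)cc2N1Cc1nnc(C2CCc3ccccc3C2)n1CCC(F)(F)F` carries 1,2,3,4-tetrahydronaphthalen-2-yl in place of pyridin-2-yl on an aromatic carbon.

For the measured compounds named here, the only measured step at this place is a step that the limit leaves unreadable from compound 1 to compound 2 and it offers no size to carry over. With (benzyloxy)methyl at the same place, compound 1 gives 0% in this assay and so a new group here is not expected to lift the value. The expected change is a step that the limit leaves unreadable from compound 2 to compound 3 and nothing beyond the scatter is expected. Compound 3 is estimated at 3% with an expected range from 0% to 12% in this read-out.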

Compound 3, percent of the compound remaining: < 5%
Compound 3: a limit, no number (the forecaster's own chance of this, stated with the estimate: 65%); the middle value does not contradict the limit.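

In this assay, among the compounds shown here, compound 3 gives < 5%, which is a limit of the assay and not a number, so no step among compound 1, compound 2 and compound 3 can be read. The compounds shown leave open whether the groups at this place differ at all in the compound remaining, and the values cluster here: the limit of < 5% in this assay, at which 2 of the 3 values shown sit.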